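A few compounds are considered here, and "the series" means these few. Any claim that something is new, unique, unknown or untested is made for them only; others in the source may bear on it.

The measured compounds and their values in an ADME assay on CCRF-HSB-2 cells (Homo sapiens) for cytotoxicity, with a stated time of 7 days; a lower number here means that less compound is tolerated, a higher number that more compound is tolerated:

Compound 1, `CCCCCOc1nc(N)nc2c1ncn2/C=C1/CC1(CO)CO`. In this assay compound 1 gives a limit of > 20000 nM.
Compound 2, `CCCCNc1nc(N)nc2c1ncn2/C=C1/CC1(CO)CO`. In this assay compound 2 gives a limit of > 20000 nM.
Compound 3, `CCCCCCSc1nc(N)nc2c1ncn2/C=C1/CC1(CO)CO`. In this assay compound 3 gives 60000 nM.

Compound 2 therefore stands at the limit of > 20000 nM in this assay, at which 2 of the 3 values shown sit, and only a limit is known for it, not a number. Compound 4, `C=CCOc1nc(N)nc2c1ncn2/C=C1/CC1(CO)CO`, differs from compound 2 by allyloxy in place of butylamino on an aromatic carbon.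

Within the data shown here, two measured steps touch the same aromatic carbon. The step that the limit leaves unreadable from compound 2 to compound 3 replaces the butylamino group that also leaves in compound 4, and the step that the two limits leave unreadable from compound 1 to compound 2 swaps an alkoxy group against it. Neither step can be read in size, so no direction beyond the usual scatter can be expected for compound 4 in this assay from these data alone.

Compound 4 is therefore expected to sit near the same limit, with an estimated step that the limit leaves unreadable from compound 2 to compound 4. The estimate for compound 4 is 40000 nM, ranging from 15000 nM to 120000 nM.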

Compound 4, half-maximal cytotoxic concentration: > 20000 nM
Compound 4 was reported as a limit (the forecaster's own chance of this, stated with the estimate: 70%); the middle value is on the limit's open side.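

With compound 4 reported as a limit in this assay, none of its steps from compound 1, compound 2 or compound 3 can be read in size. The compounds shown leave open whether the group on this aromatic carbon changes the tolerated concentration at all, and most values stand at one limit: the limit of > 20000 nM in this assay, at which 3 of the 4 values shown sit.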